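Second bromo on the ring: what compound 3 may show

The compounds below may be only part of what the source reports. "The series", "measured", "known", "first", "only" and "open" are said of these compounds alone.

Compound 1 `Nc1nc2c(s1)CC(CNC(=O)c1ccc[nH]1)CC2` gives > 30000 nM in an assay with sodium channel protein type 4 subunit alpha (Homo sapiens) as the target, read by patch clamp (on this read-out lower numbers stand for stronger inhibition and higher numbers for weaker inhibition), a limit rather than a number.
Compound 2 `Nc1nc2c(s1)CC(CNC(=O)c1cc(Br)c[nH]1)CC2` gives > 30000 nM in this assay, again a limit rather than a number.

Compound 2 therefore stands at the limit of this assay, with no number of its own. Both measured values sit there, as the limit of > 30000 nM in this assay, at which 2 of the 2 values shown sit, records. Among the measured compounds shown here, the only measured step, a step that the two limits leave unreadable from compound 1 to compound 2, is thus not readable in size or direction: it joins two limits.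

Compound 3 `Nc1nc2c(s1)CC(CNC(=O)c1cc(Br)c(Br)[nH]1)CC2` differs from compound 2 by bromo in place of hydrogen on an aromatic carbon. For the measured compounds named here, the one measured step bears on this change in kind, since it too adds bromo in place of hydrogen on an aromatic carbon of the same ring, but it gives no size to build on. Nothing in the two measured values points to a shift beyond the scatter in either direction, and the most likely outcome is that compound 3 stays at the limit as well.

Compound 3 is therefore expected to show about 40000 nM in this assay, within 10000 nM to 150000 nM. The expected step that the limit leaves unreadable from compound 2 to compound 3 is one that the limit would most probably leave unreadable once more.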

Compound 3, half-maximal inhibitory concentration: > 30000 nM
Compound 3: only a limit was reported; the forecaster's own chance of this, stated with the estimate: 85%; the middle value does not contradict the limit.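

In this assay compound 3 gives > 30000 nM as a limit and not a number. The steps among compound 1, compound 2 and compound 3 cannot be read in size or direction, since all three values rest at one limit: the limit of > 30000 nM in this assay, at which 3 of the 3 values shown sit.

The compounds shown leave open whether either added bromo changes inhibition at all.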